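The compounds below may be only part of what the source reports. "The series", "measured", "known", "first", "only" and "open" are said of these compounds alone.

Compound 2 `COc1ccc2c(=O)c(/C=C/C(=O)NCc3cccc(F)c3)coc2c1` gives 475000 nM in an ADME assay on HepG2 2.2.15 cells (Homo sapiens) for cytotoxicity, read by MTT assay, with stated times of 48 h and 9 days (a lower number here means that less compound is tolerated, a higher number that more compound is tolerated), the lowest of the three numbers seen so far. Compound 3 `Cc1ccc(CNC(=O)/C=C/c2coc3cc(O)ccc3c2=O)cc1` gives 501000 nM, a value within the scatter of that of compound 2, while compound 1 `COc1ccc2c(=O)c(/C=C/C(=O)Nc3cccc(Cl)c3)coc2c1` gives 1100000 nM, beyond it. Compound 4 `CCOc1ccc(NC(=O)/C=C/c2coc3cc(OC)ccc3c2=O)cc1` has not yet been measured; it differs from compound 2 in one place: 4-ethoxyphenyl in place of 3-fluorobenzyl on an amide-type nitrogen. Going by the values given here, the only measured step that bears on this change is the one a 2.3-fold lower number from compound 1 to compound 2 (0.36 log units; beyond the scatter), in which 3-fluorobenzyl took the place of 3-chlorophenyl on the amide-type nitrogen. The change here runs the other way, 3-fluorobenzyl leaving and 4-ethoxyphenyl entering, so a modest rise is expected, a 1.9-fold higher number from compound 2 to compound 4 (0.28 log units; within the scatter). Compound 4 is therefore estimated at 900000 nM, with a range from 400000 nM to 2000000 nM.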

Compound 4, half-maximal cytotoxic concentration: 460000 nM
Compound 4: middle estimate off by 2.0-fold (0.29 log units), on the high side; low and high end bracket the measured number.
By their numbers in this assay, from the lowest: compounds 4, 2 and 3 (each within the scatter of the next); then compound 1.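

On the amide-type nitrogen, 4-ethoxyphenyl and 3-fluorobenzyl cannot be told apart in this assay, with a 1.0-fold lower number from compound 2 to compound 4 (0.01 log units; within the scatter). Against 3-chlorophenyl, the same 4-ethoxyphenyl group gives a 2.4-fold lower number from compound 1 to compound 4 (0.38 log units; beyond the scatter), so a phenyl ring placed directly on this nitrogen does not by itself bring the higher number of compound 1. No measurement here explains these numbers. Still open, from the compounds shown here alone, is how a carboxylic acid, an amine or a longer chain on the amide-type nitrogen would read in this assay.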